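This account rests on a few compounds, and the source may have more. Where it says the series, first, only, none or still open, it means among the compounds named here.

Measured compounds:
compound 1, `COc1ccc(CSc2nc(Cc3ccccc3Br)c(C)c(=O)[nH]2)cc1`, 179000 nM;
compound 2, `Cc1c(Cc2ccccc2Br)nc(SCc2ccc([N+](=O)[O-])cc2)[nH]c1=O`, >= 246000 nM;
compound 3, `CCc1c(Cc2cc(C(F)(F)F)cc(C(F)(F)F)c2)nc(SCc2ccc(OC)cc2)[nH]c1=O`, > 249000 nM.

All three were tested in an ADME assay on MT4 cells (Homo sapiens) for cytotoxicity, read by MTT assay; on this read-out lower numbers stand for higher toxicity in this test and higher numbers for lower toxicity in this test. Compound 1 gives a number. The value of compound 2 is a limit of this assay, not a number. The value of compound 3 is likewise a limit of this assay, at the limit of > 249000 nM in this assay, at which 1 of the 3 values shown sits. Compound 1 and compound 2 differ in one place: nitro in place of methoxy on an aromatic carbon. This change gave an at least 1.3-fold higher number from compound 1 to compound 2 (0.13 log units; that floor lies within the scatter), so the two are not told apart here.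

Compound 4, `CCc1c(Cc2cc(C(F)(F)F)cc(C(F)(F)F)c2)nc(SCc2ccc([N+](=O)[O-])cc2)[nH]c1=O`, has not yet been measured. It differs from compound 3 by the same change, (nitro in place of methoxy on an aromatic carbon), at the same place. How the core of compound 3 differs from the core of compound 1 is not broken down here.

In this assay compound 4 is expected to show a step that the limit leaves unreadable from compound 3 to compound 4, because compound 1 to compound 2 gave an at least 1.3-fold higher number from compound 1 to compound 2 (0.13 log units; that floor lies within the scatter) and compound 3 already sits at a limit, > 249000 nM. The estimate for compound 4 is therefore 260000 nM, between 150000 nM and 450000 nM, most likely reported as a limit again.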

Compound 4, half-maximal cytotoxic concentration: > 242000 nM
Compound 4 ended at the assay's limit; the forecaster's own chance of this, stated with the estimate: 80%; the middle value is on the limit's open side.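

In this assay compound 4 gives > 242000 nM, which is a limit and not a number. For the compounds shown here, compound 3 also sits at a limit, and no step from compound 3 to compound 4 can be read. Going by these compounds, whether nitro in place of methoxy changes the number at all, on either core, remains open.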